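Swapping the phenyl of compound 3 for cyclohexylmethyl

A few compounds are considered here, and "the series" means these few. Any claim that something is new, unique, unknown or untested is made for them only; others in the source may bear on it.

Three compounds share a core that carries a hydroxymethyl-bearing amine side chain, and they differ only in the group on the saturated chain carbon bound to the amine nitrogen. Compound 1 `CCC(CO)NCc1nc2c(OCC3CCCCC3)cccc2[nH]1` gives 3500 nM in an assay on cells for inhibition of interleukin-5 receptor subunit alpha (Mus musculus), read by WST assay, with a stated time of 48 h, in the presence of a further agent that is not named here (on this read-out lower numbers stand for stronger inhibition and higher numbers for weaker inhibition), compound 2 `CCCC(CO)NCc1nc2c(OCC3CCCCC3)cccc2[nH]1` gives 7500 nM, and compound 3 `OCC(NCc1nc2c(OCC3CCCCC3)cccc2[nH]1)c1ccccc1` gives 20000 nM. Compound 3 thus stands highest of the three, that is, weakest on this read-out, with steps to both others beyond the scatter. Compound 4 `OCC(CC1CCCCC1)NCc1nc2c(OCC3CCCCC3)cccc2[nH]1` is the next step: cyclohexylmethyl in place of phenyl on a saturated chain carbon bound to an amine nitrogen and a saturated chain carbon. For the measured compounds named here, the steps that bear on it are a 5.7-fold higher number from compound 1 to compound 3 (0.76 log units; beyond the scatter) and a 2.7-fold higher number from compound 2 to compound 3 (0.43 log units; beyond the scatter), both showing that saturated groups at this position gave lower numbers than phenyl, while a 2.1-fold higher number from compound 1 to compound 2 (0.33 log units; beyond the scatter) shows that a larger saturated group gave a somewhat higher number. Cyclohexylmethyl is saturated yet larger than propyl, so a modest drop in number is expected for compound 4, a 2.0-fold lower number from compound 3 to compound 4 (0.30 log units; within the scatter). The estimate for compound 4 in this assay is 10000 nM, within a range from 4000 nM to 25000 nM.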

Compound 4, half-maximal inhibitory concentration: 5000 nM
Beside the measured number, compound 4's estimate is 2.0-fold (0.30 log units) above it, and the stated range covers the measured number.
By their numbers in this assay, from the lowest: compounds 1, 4 and 2 (each within the scatter of the next, the first and the last beyond it); then compound 3.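

In this assay the change to cyclohexylmethyl gives a 4.0-fold lower number from compound 3 to compound 4 (0.60 log units; beyond the scatter), so a six-membered ring at this place does not by itself bring the high number of compound 3 when the ring is non-aromatic and joined through an added carbon. The comparisons with the smaller saturated groups are a 1.5-fold lower number from compound 2 to compound 4 (0.18 log units; within the scatter) and a 1.4-fold higher number from compound 1 to compound 4 (0.15 log units; within the scatter), so the rise from ethyl to propyl does not simply continue to this bigger saturated group. No measurement given here explains these shifts.

Compound 4 differs from compound 3 both in the ring and in the added carbon, so the two changes cannot be separated, and benzyl or a directly attached cyclohexyl would be needed to do so. As far as these compounds go, how an amine or a carboxylic acid on this chain would fare also stays open.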